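From ethoxycarbonyl to isopropoxycarbonyl on the diethylamino compound

A few compounds are considered here, and "the series" means these few. Any claim that something is new, unique, unknown or untested is made for them only; others in the source may bear on it.

Compound 1 `CCOC(=O)c1c(NCCN(C)C)n(-c2ccccc2)c(=S)n(-c2ccccc2)c1=O`: 0.1 nM
Compound 2 `CC(C)OC(=O)c1c(NCCN(C)C)n(-c2ccccc2)c(=S)n(-c2ccccc2)c1=O`: 0.18 nM
Compound 3 `CCOC(=O)c1c(NCCN(CC)CC)n(-c2ccccc2)c(=S)n(-c2ccccc2)c1=O`: 0.02 nM

These three compounds were measured in a functional assay on cells (Neutrophil, Homo sapiens) for inhibition, read by transwell migration; on this read-out lower numbers stand for stronger inhibition and higher numbers for weaker inhibition. Compound 3 shows the lowest number of the three at 0.02 nM. Putting diethylamino in place of dimethylamino gave a 5.0-fold lower number from compound 1 to compound 3 (0.70 log units; beyond the scatter), which is a separate change from the one considered here.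

Compound 4 `CCN(CC)CCNc1c(C(=O)OC(C)C)c(=O)n(-c2ccccc2)c(=S)n1-c1ccccc1` keeps the diethylamino group of compound 3 and turns ethoxycarbonyl into isopropoxycarbonyl: methyl in place of hydrogen on a saturated chain carbon bound to an oxygen next to a carbonyl group and a saturated chain carbon. The same change has been measured only once, with dimethylamino in place, and it gave a 1.8-fold higher number from compound 1 to compound 2 (0.26 log units; within the scatter). Whether this holds with diethylamino has not been tested. On that single precedent, the expected result in this assay is no step beyond the scatter, with any shift more likely upward. The expected step is a 1.8-fold higher number from compound 3 to compound 4 (0.24 log units; within the scatter). For compound 4 the expected value is 0.035 nM, with an estimated range of 0.012 nM to 0.1 nM.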

Compound 4, half-maximal inhibitory concentration: 0.21 nM
For compound 4 the middle estimate is 6.0-fold (0.78 log units) below the measured one; the whole stated range lies below it.
By their numbers in this assay, from the lowest: compound 3; then compounds 1, 2 and 4 (each within the scatter of the next, the first and the last beyond it).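

In this assay the change from ethoxycarbonyl to isopropoxycarbonyl turns out to depend on the amine in the same compound, as with diethylamino in place it gives an 11-fold higher number from compound 3 to compound 4 (1.02 log units; beyond the scatter), which does not match the step seen with dimethylamino: the same change on two cores in this assay, a 1.8-fold higher number (0.26 log units; within the scatter) from compound 1 to compound 2 and an 11-fold higher number (1.02 log units; beyond the scatter) from compound 3 to compound 4, 5.8-fold (0.77 log units) apart, beyond the scatter of two such steps

Read the other way, the change from dimethylamino to diethylamino gives no step beyond the scatter when isopropoxycarbonyl is present, a 1.2-fold higher number from compound 2 to compound 4 (0.07 log units; within the scatter), so the two changes do not simply add: the same change on two cores in this assay, a 5.0-fold lower number (0.70 log units; beyond the scatter) from compound 1 to compound 3 and a 1.2-fold higher number (0.07 log units; within the scatter) from compound 2 to compound 4, 5.8-fold (0.77 log units) apart, beyond the scatter of two such steps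

Among these four, only compound 3, which pairs ethoxycarbonyl with diethylamino, stands beyond the scatter of all the others.

The compounds shown leave open whether this dependence extends to methoxycarbonyl or tert-butoxycarbonyl, or to a longer chain on the amine such as dipropylamino. They also cannot tell why the two groups interact.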